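The compounds below may be only part of what the source reports. "The series", "measured", "known", "first", "only" and "open" are said of these compounds alone.

Measured so far, in a physicochemical assay for lipophilicity, read by HPLC, measured as chromatographic lipophilicity, at pH 7.4; a higher number here means a more lipophilic compound, a lower number a more polar compound:
- compound 1 `O=C(c1cn[nH]c1)N1CCC(C(=O)N2N=CCC2c2ccccc2)CC1` gives 2.1
- compound 2 `CC(C)(C)C(=O)N1CCC1c1ccccc1` gives 5
- compound 3 `CC(C)(C)C(=O)N1N=CCC1c1ccc(C(C)(C)C)cc1` gives 8

Among these three, compound 1 stands lowest in this assay. Compound 2 sits well above it, by a gap beyond the usual scatter, and compound 3 sits higher still, the furthest of the three from compound 1. None of these pairs differs in just one place, so their values are only points of reference here.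

Compound 4 `O=C(c1cocn1)N1CCC(C(=O)N2N=CCC2c2ccccc2)CC1` has not yet been measured. It differs from compound 1 in one spot: 1,3-oxazol-4-yl in place of 1H-pyrazol-4-yl on a carbonyl carbon. The group that leaves carries a hydrogen-bond donor; the group that enters carries none and counts two hydrogen-bond acceptors instead.

No comparable single change has been measured in this set, so the expectation rests on the change itself. A small rise is expected, with the step from compound 1 to compound 4 estimated at a number 0.50 log units higher from compound 1 to compound 4 (beyond the scatter), and the possibility of no shift beyond the scatter is not ruled out. Compound 4 is therefore expected to give about 2.6 in this assay, somewhere between 1.9 and 3.3.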

Compound 4, distribution coefficient: 2.9
Compound 4: the middle estimate sits 0.30 log units below what was measured, within the range that was stated.
By their numbers in this assay, from the lowest: compound 1; then compound 4; then compound 2; then compound 3.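

Among the compounds shown here, this is the first comparison in the set between compounds that differ in one place only: in this assay, 1,3-oxazol-4-yl in place of 1H-pyrazol-4-yl on a carbonyl carbon gives a number 0.80 log units higher from compound 1 to compound 4 (beyond the scatter). The number moves clearly even though the size of the group stays the same, with 5 heavy atoms and one five-membered aromatic ring with 2 hetero atoms on each side, while the hydrogen-bond donor of the leaving group is absent from the entering one. Nothing measured here explains why the number moves.

From the compounds shown here alone, with a single step at this position, it remains open whether the same exchange would shift the number similarly on a different core. Going by these compounds, it is also open how a group of another kind on this carbonyl, such as an amine, a carboxylic acid or a longer chain, would compare.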